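Longer Alkyl Chain on the Shared Core

The source may hold more compounds than are shown below. What is called first, only, known or untested is meant among the compounds shown, and "the series" means these compounds.

compound 1 `C=C1CC(C)OC1=O`: 41000 nM
compound 2 `C=C1CC(CC)OC1=O`: 51600 nM

Among the compounds with values here, in a functional assay on NALM-6 cells (Homo sapiens) for cytotoxicity, read by MTT assay, with a stated time of 48 h (on this read-out lower numbers stand for stronger inhibition and higher numbers for weaker inhibition), compound 2 stands next to compound 1, and the only measured step, a 1.3-fold higher number from compound 1 to compound 2 (0.10 log units; within the scatter), does not separate the two. Compound 3 `C=C1CC(CCCCC)OC1=O` carries propyl in place of hydrogen on a saturated chain carbon, two bonds along the chain from a saturated ring carbon. Within the data shown here, the one step that bears on it, methyl in place of hydrogen on that chain, was small. Nothing measured speaks to a chain of this length, so for compound 3 the expected change in this assay is a 1.1-fold lower number from compound 2 to compound 3 (0.06 log units; within the scatter), no direction beyond the scatter being supported. Compound 3 is therefore estimated at 45000 nM, with a range from 15000 nM to 140000 nM.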

Compound 3, half-maximal inhibitory concentration: 23600 nM
Compound 3: middle estimate off by 1.9-fold (0.28 log units), on the high side; the measured number falls inside the stated range.
By their numbers in this assay, from the lowest: compounds 3, 1 and 2 (each within the scatter of the next, the first and the last beyond it).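

In this assay, the chain at this position produced its first step beyond the scatter: propyl in place of hydrogen gave a 2.2-fold lower number from compound 2 to compound 3 (0.34 log units; beyond the scatter), a modest step, whereas methyl in place of hydrogen had not separated compound 1 from compound 2. Against compound 1, butyl in place of hydrogen gave a 1.7-fold lower number from compound 1 to compound 3 (0.24 log units; within the scatter), which stays within the scatter, so the shift is clear only when measured from compound 2. Nothing available explains this step. The compounds shown leave open whether a longer chain would move the number further, and what a branched chain or a terminal amine would do here.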